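A few compounds are considered here, and "the series" means these few. Any claim that something is new, unique, unknown or untested is made for them only; others in the source may bear on it.

Among the compounds with values here, in a functional assay on HCT-116 cells (Homo sapiens) for inhibition, read by sulforhodamine B assay, with a stated time of 48 h (on this read-out lower numbers stand for stronger inhibition of growth and higher numbers for weaker inhibition of growth), compound 1 `CC(C)c1cc(C(=O)Nc2cccc(NC(=O)CCCCCCC(=O)NO)c2)c(O)cc1O` gives 6230 nM, the only actual number so far. Compound 2 `CC(C)c1cc(C(=O)N(c2ccc(NC(=O)CCCCCCC(=O)NO)cc2)C(C)C)c(O)cc1O` is reported only as a limit of the assay, > 10000 nM. Compound 3 `CC(C)c1cc(C(=O)N(C)c2cccc(NC(=O)CCCCCCC(=O)NO)c2)c(O)cc1O` keeps the core of compound 1 and differs from it at one place: methyl in place of hydrogen on an amide-type nitrogen. Within the data shown here, no measured pair shows this change on its own, so the expected step of a 1.2-fold lower number from compound 1 to compound 3 (0.10 log units; within the scatter) in this assay is small, with no shift beyond the usual scatter. For compound 3 the estimate is 5000 nM, with an expected range from 1500 nM to 12000 nM.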

Compound 3, concentration for 50% growth inhibition: 1170 nM
For compound 3 the middle estimate is 4.3-fold (0.63 log units) above the measured one; the measured number lies below the stated range.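

In this assay, methyl in place of hydrogen on the amide-type nitrogen gives a 5.3-fold lower number from compound 1 to compound 3 (0.73 log units; beyond the scatter). So growth inhibition does not depend on this nitrogen keeping its hydrogen, and one added carbon here is enough to move the result beyond the usual scatter. No measurement shown accounts for this gain.

As far as these compounds go, whether ethyl, a longer chain, or a chain ending in an amine or a carboxylic acid would fit on this nitrogen stays open. One step also cannot show whether methyl would act alike on another core.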